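The source may report more compounds than this note shows. Statements on the series, on what has been measured and on what is new or still open speak of the compounds shown alone.

Measured in a functional assay on MT4 cells (Homo sapiens), read by MTT assay; a lower number here means that less compound is tolerated, a higher number that more compound is tolerated:

Compound 1 `C#C[C@]1(CO)O[C@@H](n2cc(C)c(N)nc2=O)C[C@@H]1O`: 700 nM
Compound 2 `C#C[C@]1(CO)O[C@@H](n2cc(F)c(N)nc2=O)C[C@@H]1O`: > 100000 nM, a limit
Compound 3 `C#C[C@]1(CO)O[C@@H](n2cc(Br)c(N)nc2=O)C[C@@H]1O`: > 100000 nM, a limit

Compound 3 has no number of its own, only a limit, > 100000 nM. Compound 3 thus stands at the limit of > 100000 nM in this assay, at which 2 of the 3 values shown sit. Compound 2 shares that limit.

The move to compound 4 `C#C[C@]1(CO)O[C@@H](n2cc(I)c(N)nc2=O)C[C@@H]1O` is a single exchange, iodo in place of bromo on an aromatic carbon. Among the compounds with values here, three measured steps bear on it. Fluoro in place of methyl gave an at least 140-fold higher number from compound 1 to compound 2 (2.15 log units; beyond the scatter), and bromo in place of methyl gave an at least 140-fold higher number from compound 1 to compound 3 (2.15 log units; beyond the scatter). Both are large and beyond the scatter. The closest comparison, bromo in place of fluoro, is a step that the two limits leave unreadable from compound 2 to compound 3, so it gives no size to carry over.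

Within the data shown here, in this series, each exchange of methyl for fluoro or bromo ended at the limit, and no measured compound goes against that. Going by these compounds, compound 4 is therefore expected to stay close to compound 3 in this assay, with no step beyond the scatter, although iodo itself is untested and any departure could only be seen as a lower number. For compound 4 the estimated value is 100000 nM, with an expected range from 20000 nM to 200000 nM. The expected step is a number no higher from compound 3 to compound 4 (the limit leaves the size open).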

Compound 4, half-maximal cytotoxic concentration: > 100000 nM
Compound 4: no number, only a limit; the forecaster's own chance of this, stated with the estimate: 75%; the middle value lies on the limit itself.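

In this assay iodo now joins fluoro and bromo at this position, ortho to an amino group, and all three halogens shown end at the same limit, leaving compound 1, with methyl, as the only compound with a number: the limit of > 100000 nM in this assay, at which 3 of the 4 values shown sit. The one step that can be read is an at least 140-fold higher number from compound 1 to compound 4 (2.15 log units; beyond the scatter) and it extends to iodo what fluoro and bromo had already shown for the exchange of methyl, although its size has only a lower end, set by the limit. The steps among compound 2, compound 3 and compound 4 cannot be read, as each of these compounds has only a limit, so the halogens cannot be ordered against one another.

The compounds shown leave open whether the low number of compound 1 belongs to methyl alone or would also appear with ethyl, chloro or a plain hydrogen at this position. They also leave open how far the three halogen compounds lie beyond the limit, and whether any of them differ once a number can be read.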